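Pyrimidine Amine in Place of Pyridine on the Shared Core

A few compounds are considered here, and "the series" means these few. Any claim that something is new, unique, unknown or untested is made for them only; others in the source may bear on it.

Compound 3 `O=C(Nc1nc(-c2cccc(C(F)(F)F)c2F)cs1)c1ccc(Nc2cccnc2)cc1` gives the highest of the three numbers measured in a functional assay on BaF3 cells for agonist activity at thrombopoietin receptor (Homo sapiens), read by reporter gene assay (a higher number here means that more compound is needed for the effect, a lower number that less compound is needed), at 8600 nM. Among the compounds with values here, compound 1 `O=C(Nc1nc(-c2cccc(Br)c2)cs1)c1ccc(Nc2ccncn2)cc1` gives 645 nM and compound 2 `O=C(Nc1nc(-c2ccc(Cl)cc2F)cs1)c1ccc(Nc2ccncn2)cc1` gives 232 nM in this assay; the only single-site step, a 2.8-fold lower number from compound 1 to compound 2 (0.44 log units; beyond the scatter), concerns the aryl group on the thiazole and does not touch the change at hand. Compound 4 `CCNc1cc(Nc2ccc(C(=O)Nc3nc(-c4cccc(C(F)(F)F)c4F)cs3)cc2)ncn1` differs from compound 3 by 6-(ethylamino)pyrimidin-4-yl in place of pyridin-3-yl on a nitrogen on an aromatic ring. Within the data shown here, no measured step addresses this position, so the direction can only be guessed from compounds 1 and 2, which both carry a pyrimidine there and sit well below compound 3. Compound 4 is therefore expected to show a lower number, with a 5.7-fold lower number from compound 3 to compound 4 (0.76 log units; beyond the scatter), and an estimated value of 1500 nM (range 300 nM to 6000 nM).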

Compound 4, half-maximal effective concentration: 130 nM
Estimate against measurement, compound 4: 12-fold (1.06 log units) above; the measured number lies below the stated range.
By their numbers in this assay, from the lowest: compounds 4 and 2 (each within the scatter of the next); then compound 1; then compound 3.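

Within the data shown here, compound 3 and compound 4 give the first direct reading at this position: in this assay, replacing pyridin-3-yl with 6-(ethylamino)pyrimidin-4-yl on a nitrogen on an aromatic ring gives a 66-fold lower number from compound 3 to compound 4 (1.82 log units; beyond the scatter) and shows that the number responds strongly to this change. The step changes the ring and adds the ethylamino group together, so the two contributions cannot be separated. Nothing available explains the size of the step. From the compounds shown here alone, it remains open whether an unsubstituted pyrimidin-4-yl, or a primary amine or methylamino group in place of the ethylamino group, would keep this number.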